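A few compounds are considered here, and "the series" means these few. Any claim that something is new, unique, unknown or untested is made for them only; others in the source may bear on it.

Measured so far:
Compound 1 `O=C(O)c1csc([C@H]2CC[C@@H]3[C@@H](COc4cccc(F)c4)[C@H](O)C[C@@H]3O2)n1` gives > 10000 nM in an assay on HEK293 cells for agonist activity at prostaglandin E2 receptor EP2 subtype (Homo sapiens), read by a beta-galactosidase reporter and beta-arrestin recruitment, with a stated time of 90 min (on this read-out higher numbers stand for an effect only at larger amounts of compound and lower numbers for an effect already at smaller amounts), a limit.
Compound 2 `O=C(O)c1csc([C@H]2CC[C@@H]3[C@@H](COc4cccc(OC(F)(F)F)c4)[C@H](O)C[C@@H]3O2)n1` gives 69 nM in this assay.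
Compound 3 `O=C(O)c1csc([C@H]2CC[C@@H]3[C@@H](/C=C/CCCOc4ccccc4)[C@H](O)C[C@@H]3O2)n1` gives > 10000 nM in this assay, a limit.

Compound 1 stands at the limit of > 10000 nM in this assay, at which 2 of the 3 values shown sit, so no number is known for it. The only single-point step among these compounds, an at least 140-fold lower number from compound 1 to compound 2 (2.16 log units; beyond the scatter), shows that the group on the aromatic ring can move the read-out by a large amount. Compound 4 `O=C(O)c1csc([C@H]2CC[C@@H]3[C@@H](COc4ccccc4Cl)[C@H](O)C[C@@H]3O2)n1` differs from compound 1 by 2-chlorophenyl in place of 3-fluorophenyl on an oxygen on a saturated carbon. This again alters the group on that ring, but to a different group than in compound 2, so the measured step gives only a weak pointer. Compound 4 is expected near 3000 nM, within 300 nM to 30000 nM. The expected step from the limit is an at least 3.3-fold lower number from compound 1 to compound 4 (0.52 log units; beyond the scatter), and a further limit is estimated as quite possible.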

Compound 4, half-maximal effective concentration: 203 nM
For compound 4 the middle estimate is 15-fold (1.17 log units) above the measured one, outside the stated range (below it).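

The step of an at least 49-fold lower number from compound 1 to compound 4 (1.69 log units; beyond the scatter) comes with 2-chlorophenyl in place of 3-fluorophenyl on an oxygen on a saturated carbon. A large move at this position therefore does not depend on the trifluoromethoxy group of compound 2; a single chlorine on the ring also gives a measured value. Compound 1 remains a limit, so the full size of the step is unknown: the limit of > 10000 nM in this assay, at which 2 of the 4 values shown sit.

The halogen and its ring position change together here, so their contributions cannot be separated. Going by these compounds, how a nitrile or an amine on this ring would read out remains open.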